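Ethyl at the saturated ring carbon: compound 3 to compound 4

This account rests on a few compounds, and the source may have more. Where it says the series, first, only, none or still open, it means among the compounds named here.

Measured compounds:
compound 1 `CCC1(CCCCN2CCN(c3ccc(Cl)c(Cl)c3)CC2)C(=O)Nc2ccccc21` — "not determined" (no result reported)
compound 2 `CCC1(CCCCN2CCN(c3cccc(Cl)c3)CC2)C(=O)Nc2cc(F)ccc21` — "not determined" (no result reported)
compound 3 `O=C1Nc2ccccc2C1CCCCN1CCN(c2cccc(Cl)c2)CC1` — > 10 mg/kg

In a functional assay on the whole organism (strain NMRI) with Mus musculus as the target, with a stated time of 5 min (on this read-out lower numbers stand for an effect already at smaller amounts and higher numbers for an effect only at larger amounts of compound), compound 1 has no result reported, and the same holds for compound 2. For the measured compounds named here, compound 3 is the only member with an entry, and that entry is a limit of the assay, not a number: in this assay compound 3 gives > 10 mg/kg. Compound 3 therefore stands at the limit of > 10 mg/kg in this assay, at which 1 of the 3 values shown sits, and nothing among the values shown lets one place it higher or lower than that.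

Compound 4 `CCC1(CCCCN2CCN(c3cccc(Cl)c3)CC2)C(=O)Nc2ccccc21` has not yet been measured. It differs from compound 3 in one place: ethyl in place of hydrogen on a saturated ring carbon.

Going by the values given here, no step between measured compounds is available, so the size or direction of the change in this assay cannot be read from the series itself. With compound 3 sitting at a limit, any step to compound 4 is expected to be either none beyond the scatter or a move toward a measurable dose. The estimate for compound 4 in this assay is 10 mg/kg, with a range from 3 mg/kg to 30 mg/kg, which is expected to mean a step of a number no higher from compound 3 to compound 4 (the limit leaves the size open).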

Compound 4, minimum effective dose: > 10 mg/kg
Compound 4 gave a limit, no number; the forecaster's own chance of this, stated with the estimate: 60%; the middle value lies on the limit itself.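

In this assay compound 3 gives > 10 mg/kg, a limit and not a number. Compound 4 gives > 10 mg/kg, also a limit, so no step can be read between compound 3 and compound 4. The compounds shown leave open whether ethyl in place of hydrogen on a saturated ring carbon shifts the minimum effective dose at all.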